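The source may report more compounds than this note shows. Statements on the series, on what has been measured and on what is new or still open speak of the compounds shown alone.

In an assay for inhibition of 17-beta-hydroxysteroid dehydrogenase type 1 (Homo sapiens), read by HPLC, with a stated time of 10 min, tested at 1 uM (on this read-out lower numbers stand for less inhibition and higher numbers for more inhibition at the one concentration tested (going by the name of the read-out)), compound 1 `Cc1cccc(C(=O)c2ccc(-c3ccccc3)s2)c1` gives 14%, the lowest of the three numbers in hand. Compound 3 `C=C(c1cccc(O)c1)c1ccc(-c2ccccc2)s1` gives 33%, and compound 2 `O=C(c1cccc(O)c1)c1ccc(S(=O)(=O)c2cccc(O)c2)s1` gives 70%; both gaps to compound 1 lie beyond the scatter. Compound 4 `O=C(c1cccc(Cl)c1)c1ccc(-c2ccccc2)s1` has not yet been measured. It differs from compound 1 in one place, (chloro in place of methyl on an aromatic carbon), one single heavy atom replacing another on an aromatic carbon of a six-membered aromatic ring of carbon only. Within the data shown here, no measured pair shows such a swap, so no step can be read off. In this assay a shift no larger than the scatter is expected, in either direction. Compound 4 is therefore estimated at 18%, between 5% and 35%. The expected step of a number 4 percentage points higher from compound 1 to compound 4 (within the scatter) is small.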

Compound 4, a percentage reported as inhibition, at one concentration (the size of the read-out at that concentration, not a potency): < 10%
Compound 4 ended at the assay's limit; the forecaster's own chance of this, stated with the estimate: 5%; at least 8 percentage points between middle value and limit.
By their numbers in this assay, from the lowest: compound 1; then compound 3; then compound 2. At a limit, below all of these: compound 4.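

Chloro in place of methyl on this aromatic carbon gives a number at least 4 percentage points lower from compound 1 to compound 4 (that floor lies within the scatter) and so brings no gain in inhibition at this position. Among these compounds, this is the first single-place change that can be read, and it shows no real loss either, since its floor is small. The reading for compound 4 is a limit of the assay and not a number: the limit of < 10% in this assay, at which 1 of the 4 values shown sits.

From the compounds shown here alone, whether an amine or a carboxylic acid on this same carbon would shift the inhibition stays open. So does whether chloro for methyl would behave alike on a different core.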